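Trifluoromethyl Added to the Phenyl Ring of Compound 2

This account rests on a few compounds, and the source may have more. Where it says the series, first, only, none or still open, it means among the compounds named here.

Two pyrazoline-thiazoles were tested in a functional assay on MCF7 cells (Homo sapiens) for antiproliferative activity, read by MTT assay, with a stated time of 48 h; on this read-out higher numbers stand for weaker inhibition and lower numbers for stronger inhibition. Compound 1 `COc1ccc(C2=NN(c3nc(-c4ccc(C(F)(F)F)cc4)cs3)C(c3cccs3)C2)cc1` gives 45700 nM in this assay. Compound 2 `Brc1ccc(C2=NN(c3nc(-c4ccccc4)cs3)C(c3cccs3)C2)cc1` gives 6790 nM in this assay, the lowest of the two numbers, and compound 1 stands a clear distance above it. Compound 2 and compound 1 differ in two places, so their values alone cannot be assigned to one change.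

Compound 3 `FC(F)(F)c1ccc(-c2csc(N3N=C(c4ccc(Br)cc4)CC3c3cccs3)n2)cc1` keeps the bromophenyl of compound 2 and differs from it by trifluoromethyl in place of hydrogen on an aromatic carbon. Among the compounds with values here, no measured pair isolates this change. Because compound 1 gives 45700 nM while also carrying a trifluoromethyl group, some weakening is plausible, but compound 1 also carries methoxy in place of bromine, so the attribution is uncertain. Compound 3 is therefore expected to sit a 1.8-fold higher number from compound 2 to compound 3 (0.25 log units; within the scatter) from compound 2, a modest weakening. Compound 3 is estimated at 12000 nM, within 4000 nM to 40000 nM.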

Compound 3, half-maximal inhibitory concentration: 7810 nM
Compound 3: the middle estimate sits 1.5-fold (0.19 log units) above what was measured; the measured number falls inside the stated range.
By their numbers in this assay, from the lowest: compounds 2 and 3 (each within the scatter of the next); then compound 1.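

In this assay, trifluoromethyl in place of hydrogen on an aromatic carbon, para to a large group, gives a step within the scatter (a 1.2-fold higher number from compound 2 to compound 3 (0.06 log units; within the scatter)), so with bromo present this position tolerates the larger group without a readable change. With trifluoromethyl held in common, bromo in place of methoxy gives a step beyond the scatter (a 5.9-fold lower number from compound 1 to compound 3 (0.77 log units; beyond the scatter)), which ties the high number of compound 1 to the methoxy-for-bromo change and not to trifluoromethyl. Nothing measured here gives a reason for either step.

The compounds shown leave open whether an amine or a carboxylic acid at this same place would move the number beyond the scatter. They also leave open whether chloro or hydroxyl in place of bromo would sit nearer compound 3 or compound 1.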